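The source may hold more compounds than are shown below. What is called first, only, known or untested is meant among the compounds shown, and "the series" means these compounds.

Measured so far:

Compound 1, `COc1ccc(C2=C(c3cc(OC)c(OC)c(OC)c3)C(=O)CC2O[SiH2]C(C)(C)C)cc1`: in an ADME assay on HT-29 cells (Homo sapiens) for cytotoxicity, read by MTT assay, with a stated time of 72 h (a higher number here means a weaker inhibitor, a lower number a stronger inhibitor), compound 1 gives only a limit of the assay, > 100 ug/mL.
Compound 2, `COc1ccc(C2=C(c3cc(OC)c(OC)c(OC)c3)CC(O)C2=O)cc1[N+](=O)[O-]`: in this assay compound 2 likewise gives only a limit, > 100 ug/mL.
Compound 3, `COc1ccc(C2=C(c3cc(OC)c(OC)c(OC)c3)C(=O)CC2O)cc1`: in this assay compound 3 gives a number, 15 ug/mL.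

Compound 3 and compound 1 differ in a single place: a group of 5 heavy atoms (4 carbon, 1 silicon; no ring) in place of a hydrogen atom, on an oxygen on a saturated carbon. That change gave an at least 6.6-fold higher number from compound 3 to compound 1 (0.82 log units; beyond the scatter), and since the number for compound 1 is a limit, the full size of that step is not known. Compound 2 and compound 3 carry different cores; the difference between the two cores is not broken down here.

Compound 4, `COc1ccc(C2=C(c3cc(OC)c(OC)c(OC)c3)CC(O[SiH2]C(C)(C)C)C2=O)cc1[N+](=O)[O-]`, has not yet been measured in this assay. It stands to compound 2 exactly as compound 1 stands to compound 3: a group of 5 heavy atoms (4 carbon, 1 silicon; no ring) in place of a hydrogen atom, on an oxygen on a saturated carbon. The place is described in the same words for both pairs, so this is the same change, made a second time on the other core.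

For compound 4 the expected step from compound 2 is a step that the limit leaves unreadable from compound 2 to compound 4, meaning no real movement that the assay could show. Going by the values given here, this rests on compound 2 already sitting at the limit of > 100 ug/mL in this assay, at which 2 of the 3 values shown sit, and on the only measured instance of the change, which carried compound 1 to that same limit. Compound 4 is therefore expected to give about 150 ug/mL, most likely reported only as a limit, with a plausible range from 100 ug/mL to 400 ug/mL.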

Compound 4, half-maximal inhibitory concentration: > 100 ug/mL
Compound 4: no number, only a limit (the forecaster's own chance of this, stated with the estimate: 90%); the middle value is on the limit's open side.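

Compound 2 and compound 4 both give only a limit in this assay, so the step between them cannot be read, and both stop at the same point: the limit of > 100 ug/mL in this assay, at which 3 of the 4 values shown sit. The compounds shown leave open what true values lie behind these limits, and so whether the change does on the core of compound 2 what it did on the core of compound 3.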